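Tail Flick Activity: From Compound 2 to Compound 3

The source may report more compounds than this note shows. Statements on the series, on what has been measured and on what is new or still open speak of the compounds shown alone.

In a functional assay on the whole organism (Tail, strain ICR) with Mus musculus as the target, in the tail flick test, with a stated time of 60 min, at a dose of 25 umol/kg by the oral route (on this read-out lower numbers stand for a weaker effect and higher numbers for a stronger effect at the one dose given), the two measured compounds gave these numbers:

compound 1, `O=C(CN(c1nc(Cl)nc2[nH]cnc12)C1CC1)N[C@@H](CCC(=O)OCc1ccccc1)C(=O)OCc1ccccc1`: compound 1 gives 53.7%
compound 2, `NC(=O)CC[C@H](NC(=O)CN(c1nc(Cl)nc2[nH]cnc12)C1CC1)C(=O)OCc1ccccc1`: compound 2 gives 33.1%

For the measured compounds named here, compound 2 stands lowest of the two, the only step to it being a number 20.6 percentage points lower from compound 1 to compound 2 (beyond the scatter). Compound 3, `CC(C)C[C@H](NC(=O)CN(c1nc(Cl)nc2[nH]cnc12)C1CC1)C(=O)OCc1ccccc1`, is not yet measured. It differs from compound 2 by isopropyl in place of carbamoylmethyl on a saturated chain carbon, two bonds along the chain from an amide-type nitrogen and a carbonyl carbon. Going by the values given here, no measured step changes the same part of the molecule; the one step known, from compound 1 to compound 2, replaced a benzyloxy group at a carbonyl carbon with an amino group and lowered the number beyond the scatter. Compound 3 removes that same carbamoyl unit altogether, so a modest step upward in this assay is expected, rather than a loss. Compound 3 is therefore estimated at 45%, within 25% to 65%, a step of a number 11.9 percentage points higher from compound 2 to compound 3 (beyond the scatter).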

Compound 3, a percentage reported as activity, at one dose (the size of the read-out at that dose, not a potency): 27.3%
For compound 3 the middle estimate is 17.7 percentage points above the measured one; the measured number falls inside the stated range.
By their numbers in this assay, from the lowest: compounds 3 and 2 (each within the scatter of the next); then compound 1.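

In this assay, isopropyl in place of carbamoylmethyl on this saturated chain carbon gives a number 5.8 percentage points lower from compound 2 to compound 3 (within the scatter) and so shows that a side chain with a hydrogen-bond donor and acceptor and one with neither read alike here. Isopropyl in place of (benzyloxycarbonyl)methyl at the same carbon gives a number 26.4 percentage points lower from compound 1 to compound 3 (beyond the scatter) and so sets the side chain of compound 1 apart from those of compound 2 and compound 3, which stay together at the lower level. No evidence is available that explains this result.

As far as these compounds go, whether a carboxylic acid at the end of this side chain, or a longer chain ending in a phenyl ring, would read like compound 1 or like compound 2 and compound 3 remains open. Also open, from the compounds shown here alone, is what a carboxylic acid in place of the benzyl ester shared by all three compounds would give.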